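The compounds below may be only part of what the source reports. "The series", "measured", "known", "first", "only" and "open" are said of these compounds alone.

Compound 1 `Oc1ccc(-c2cn(Cc3ccccc3)cc2-c2ccc(O)cc2)cc1`, compound 2 `COc1cccc(Cn2cc(-c3ccc(O)cc3)c(-c3ccc(O)cc3)c2)c1` and compound 3 `COc1ccc(Cn2cc(-c3ccc(O)cc3)c(-c3ccc(O)cc3)c2)c(OC)c1` have been measured in a functional assay on NCI-H1299 cells (Homo sapiens) for antiproliferative activity, read by fluorescence and resazurin assay, with a stated time of 48 h; on this read-out lower numbers stand for stronger inhibition and higher numbers for weaker inhibition: compound 1 gives 26900 nM, compound 2 gives 25300 nM and compound 3 gives 31600 nM. Compound 4 `COc1ccc(Cn2cc(-c3ccc(O)cc3)c(-c3ccc(O)cc3)c2)c(OC)c1OC` has not yet been measured. The change that turns compound 3 into compound 4, (methoxy in place of hydrogen on an aromatic carbon), is of the same kind as the change from compound 1 to compound 2, (methoxy in place of hydrogen on an aromatic carbon), which produced a 1.1-fold lower number from compound 1 to compound 2 (0.03 log units; within the scatter). The places are not identical: in compound 4 the entering group sits ortho to two methoxy groups and meta to a large group, whereas in compound 2 it sits only meta to a large group. The cores of compound 1 and compound 3 differ by 2,4-dimethoxyphenyl in place of phenyl on a saturated chain carbon bound to an aromatic nitrogen. Resting on the earlier step, compound 4 is expected to show a 1.0-fold higher number from compound 3 to compound 4 (0.02 log units; within the scatter) in this assay. Compound 4 is therefore estimated at 33000 nM.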

Compound 4, half-maximal inhibitory concentration: 25100 nM
Compound 4: middle estimate off by 1.3-fold (0.12 log units), on the high side; measured number inside the range.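

In this assay, methoxy in place of hydrogen on an aromatic carbon gave a 1.3-fold lower number from compound 3 to compound 4 (0.10 log units; within the scatter). Set beside the earlier step, this result does not differ from it: the same change on two cores in this assay, a 1.1-fold lower number (0.03 log units; within the scatter) from compound 1 to compound 2 and a 1.3-fold lower number (0.10 log units; within the scatter) from compound 3 to compound 4, 1.2-fold (0.07 log units) apart, within the scatter of two such steps. Going by these compounds alone, the change thus carried across these two cores with little effect on the number, but that rests on only two pairs, with the methoxy entering at different places, and it does not show that the same would hold on other cores.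

The compounds shown leave open whether an amine or a carboxylic acid at such an aromatic carbon would move the number beyond the scatter. They also leave open whether a longer chain to the aromatic nitrogen would do so.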